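Methyl on the ring amide nitrogen of compound 2

The compounds below may be only part of what the source reports. "The series", "measured", "known", "first", "only" and "open" are said of these compounds alone.

In a functional assay on L1210 cells (Mus musculus) for cytotoxicity (a lower number here means a stronger inhibitor, a higher number a weaker inhibitor), the three measured compounds stand as follows:
Compound 1, `COc1ccc(C[C@H]2C(=O)N[C@@H](C)C(=O)N(C)CC(=O)N(C)CC(=O)N[C@@H](C)C(=O)N[C@@H](C)C(=O)N2C)cc1`, gives a limit: > 100 ug/mL.
Compound 2, `O=C1CCc2ccc(cc2)Oc2cccc(c2)CCN1`, gives a limit: > 100 ug/mL.
Compound 3, `CN[C@H]1Cc2ccc(O)c(c2)Oc2ccc(cc2)C[C@@H](C(=O)O)N(C)C(=O)[C@H](C)NC(=O)[C@H](Cc2ccc(OC)cc2)N(C)C(=O)[C@H](C)NC(=O)[C@H](C)NC1=O`, gives 10 ug/mL.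

Compound 2 thus sits at the limit of > 100 ug/mL in this assay, at which 2 of the 3 values shown sit, and only compound 3 carries a number. Compound 4, `CN1CCc2cccc(c2)Oc2ccc(cc2)CCC1=O`, differs from compound 2 in one place: methyl in place of hydrogen on an amide-type nitrogen in a ring. Going by the values given here, no step between measured compounds is known, so there is no measured guide for this change. The expected step from compound 2 to compound 4, a number no higher from compound 2 to compound 4 (the limit leaves the size open), is none beyond the scatter, and compound 4 is expected to remain at the limit. Compound 4 is estimated at 100 ug/mL, within 30 ug/mL to 300 ug/mL.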

Compound 4, half-maximal inhibitory concentration: > 100 ug/mL
Compound 4 was reported as a limit (the forecaster's own chance of this, stated with the estimate: 80%); the middle value lies on the limit itself.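

Going by these compounds alone, compound 2 and compound 4 are both reported only as limits, so no step between them can be read. The compounds shown leave open what methyl in place of hydrogen on an amide-type nitrogen in a ring does in this assay.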